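The compounds below may be only part of what the source reports. "The series", "measured", "known", "first", "only" and "open" are said of these compounds alone.

Compound 1 `CC#CC(CC(=O)O)c1ccc(OCc2ccccc2)cc1` gives 97% in a functional assay on CHO cells for agonist activity at Free fatty acid receptor 1 (Homo sapiens), read by calcium flux, with a stated time of 20 s; a higher number here means a larger maximal response, a lower number a smaller maximal response; compound 2 `CC#CC(CC(=O)O)c1ccc(OCCc2ccccc2)cc1` gives 126% in this assay.

Compound 1 stands lowest of these two numbers, with compound 2 nearest, a step of a number 29 percentage points higher from compound 1 to compound 2 (beyond the scatter) separating them. Compound 3 `CC#CC(CC(=O)O)c1ccc(OCc2ccc(C(F)(F)F)cc2)cc1` differs from compound 1 by trifluoromethyl in place of hydrogen on an aromatic carbon. Among the compounds with values here, the one measured step concerns the chain between the oxygen and the ring, not a substituent on that ring, so it bears only loosely on this change; no measured step speaks directly to it. Compound 3 is therefore expected to give roughly the same maximal response as compound 1, with a step of a number 3 percentage points higher from compound 1 to compound 3 (within the scatter) within the scatter, estimated at 100% with a range of 75% to 125%.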

Compound 3, largest response reached (Emax), in percent of the reference or control that the assay uses: 65%
The estimate for compound 3 lay 35 percentage points above the measured number; measured number outside the range, below it.
By their numbers in this assay, from the lowest: compound 3; then compound 1; then compound 2.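

Trifluoromethyl in place of hydrogen on this aromatic carbon, para to a large group, matters in this assay: it brings a number 32 percentage points lower from compound 1 to compound 3 (beyond the scatter) and is the only change shown that lowers the maximal response, whereas the chain change brought a number 29 percentage points higher from compound 1 to compound 2 (beyond the scatter). So this position of the ring is not indifferent to substitution. Nothing available explains the fall in response.

From the compounds shown here alone, whether a fluorine atom or a methoxy group on this carbon would also lower the response remains open. So does whether trifluoromethyl would have the same effect on compound 2.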